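Cyclohexenyl in place of propyl: expected shift for compound 4

The source may hold more compounds than are shown below. What is called first, only, known or untested is meant among the compounds shown, and "the series" means these compounds.

Measured so far:
compound 1, `CCCc1nc(C(F)(F)F)ccc1CNC(=O)C(C)c1ccc(NS(C)(=O)=O)c(F)c1`: 22.7 nM
compound 2, `CCC1CCC(c2nc(C(F)(F)F)ccc2CNC(=O)[C@@H](C)c2ccc(NS(C)(=O)=O)c(F)c2)CC1`: 0.2 nM
compound 3, `C[C@H](C(=O)NCc1ccc(C(F)(F)F)nc1C1CC2CCC1C2)c1ccc(NS(C)(=O)=O)c(F)c1`: 0.8 nM

In an assay on CHO cells for antagonist activity at transient receptor potential cation channel subfamily V member 1 (Homo sapiens), read by FLIPR and calcium flux (a higher number here means a weaker inhibitor, a lower number a stronger inhibitor), compound 1 gives the highest of the three numbers and is the weakest inhibitor of the set; compound 3 comes nearest to it and compound 2 lies furthest from it. Compound 4, `CC(C(=O)NCc1ccc(C(F)(F)F)nc1C1=C[C@H](C)CCC1)c1ccc(NS(C)(=O)=O)c(F)c1`, has not yet been measured. It differs from compound 1 in one place: 3-methylcyclohex-1-en-1-yl in place of propyl on an aromatic carbon. Going by the values given here, no measured pair covers this exact exchange. Among the compounds with values here, the only step between compounds differing in one place, a 4.0-fold higher number from compound 2 to compound 3 (0.60 log units; beyond the scatter), swaps one ring group for another at the same aromatic carbon and is modest in size. The values of compound 1 and compound 2, which carry propyl and a six-membered ring at that carbon but also differ elsewhere, show that a ring group there goes with a far lower number. A large drop is therefore expected for compound 4, a 15-fold lower number from compound 1 to compound 4 (1.18 log units; beyond the scatter), bringing it near compound 2 and compound 3. In this assay compound 4 is estimated at 1.5 nM, with a range from 0.4 nM to 6 nM.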

Compound 4, inhibition constant: 0.1 nM
Compound 4: middle estimate off by 15-fold (1.18 log units), on the high side, and the stated range ends above it.
By their numbers in this assay, from the lowest: compounds 4 and 2 (each within the scatter of the next); then compound 3; then compound 1.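

In this assay, going by these compounds alone, a 230-fold lower number from compound 1 to compound 4 (2.36 log units; beyond the scatter) gives the first reading of this position on the aromatic carbon next to the ring nitrogen in which nothing else in the molecule changes, so the link between a ring group and a far lower number no longer rests on a pair that also differs elsewhere. This step is much larger than a 4.0-fold higher number from compound 2 to compound 3 (0.60 log units; beyond the scatter), which exchanges one ring group for another at the same carbon, so among the shown pairs, replacing the open propyl chain with 3-methylcyclohex-1-en-1-yl has the larger effect. No measurement at hand explains the size of this step.

The exchange adds a ring, a double bond, a methyl group and a defined stereocentre at once, so the step cannot be divided among these features, and the opposite configuration of the methyl-bearing carbon remains an open comparison. The compounds shown also leave open whether a ring is needed at all, since a longer chain such as hexyl or a nitrogen-containing ring such as piperidine at this carbon could give a quite different number.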